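Propyl carbamate in place of the aryl carbamate

The source may hold more compounds than are shown below. What is called first, only, known or untested is meant among the compounds shown, and "the series" means these compounds.

Compound 1 `COc1nc(C)c(Nc2nc(Cl)cn([C@H](CO)C3CC3)c2=O)cc1C` gives 88 nM in an assay on frontal cortex for displacement of a labelled ligand from corticotropin-releasing factor receptor 1 (Rattus norvegicus), with a stated time of 2 h; on this read-out lower numbers stand for stronger inhibition and higher numbers for weaker inhibition.
Compound 2 `COc1nc(C)c(Nc2nc(Cl)cn([C@H](COC(=O)Nc3cccc(C#N)c3)C3CC3)c2=O)cc1C` gives 1.3 nM in this assay.
Compound 3 `COc1ccc(NC(=O)OC[C@H](C2CC2)n2cc(Cl)nc(Nc3cc(C)c(OC)nc3C)c2=O)c(C)n1` gives 9.2 nM in this assay.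

Compound 3 stands second of the three: its number lies beyond the scatter from both neighbours, a 7.1-fold higher number from compound 2 to compound 3 (0.85 log units; beyond the scatter) and a 9.6-fold lower number from compound 1 to compound 3 (0.98 log units; beyond the scatter). Compound 4 `CCCNC(=O)OC[C@H](C1CC1)n1cc(Cl)nc(Nc2cc(C)c(OC)nc2C)c1=O` carries the change (propyl in place of 6-methoxy-2-methylpyridin-3-yl on an amide-type nitrogen). Within the data shown here, two measured steps bear on it. The carbamate itself matters: a 68-fold lower number from compound 1 to compound 2 (1.83 log units; beyond the scatter) and a 9.6-fold lower number from compound 1 to compound 3 (0.98 log units; beyond the scatter) both show that a carbamoyl group on the oxygen lowers the number. The group on the amide-type nitrogen matters as well, since a 7.1-fold higher number from compound 2 to compound 3 (0.85 log units; beyond the scatter). Among the measured compounds shown here, no measured step swaps the aromatic ring of the carbamate for a chain, so the direction is an inference: a carbamate should still be better than the free alcohol of compound 1, but with the ring removed the number is expected to rise above compound 3. Compound 4 is therefore estimated at 30 nM, within 8 nM to 120 nM, a step of a 3.3-fold higher number from compound 3 to compound 4 (0.51 log units; beyond the scatter) expected toward weaker binding.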

Compound 4, half-maximal inhibitory concentration: 10 nM
Beside the measured number, compound 4's estimate is 3.0-fold (0.48 log units) above it, within the range that was stated.
By their numbers in this assay, from the lowest: compound 2; then compounds 3 and 4 (each within the scatter of the next); then compound 1.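

In this assay, the step from the free alcohol does not depend on an aromatic ring on the amide-type nitrogen: propylcarbamoyl in place of hydrogen on the oxygen gives an 8.8-fold lower number from compound 1 to compound 4 (0.94 log units; beyond the scatter), and propyl, which has no ring, cannot be told apart from 6-methoxy-2-methylpyridin-3-yl, with a 1.1-fold higher number from compound 3 to compound 4 (0.04 log units; within the scatter). The 3-cyanophenyl group remains separate from propyl, with a 7.7-fold higher number from compound 2 to compound 4 (0.89 log units; beyond the scatter), and with the 6-methoxy-2-methylpyridin-3-yl group level with propyl, an aromatic ring at this place does not by itself bring the lowest number. Nothing available accounts for this difference between the groups.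

Still open, on these data alone, is whether a longer chain such as butyl, a branched chain such as isopropyl or a chain ending in an amine would stay at this level. Also open, as far as these compounds go, is whether an unsubstituted phenyl would sit with propyl or with 3-cyanophenyl.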